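A few compounds are considered here, and "the series" means these few. Any claim that something is new, unique, unknown or untested is made for them only; others in the source may bear on it.

Compound 2 `Cc1ccc(-c2nc3c(=O)n(C)c(=O)n(C)c3[nH]2)cc1` gives 0.8 nM in an assay for binding affinity to adenosine receptor A1 (Bos taurus) (a lower number here means a stronger inhibitor, a higher number a weaker inhibitor), the second lowest of the three numbers measured. Compound 1 `CCCn1c(=O)c2nc(-c3ccc(S(=O)(=O)NCCCC(=O)OCC)cc3)[nH]c2n(CCC)c1=O` gives 0.24 nM, whereas compound 3 `Cc1ccc(-c2nc3c(=O)n(C)c(=O)n(C)c3[nH]2)c(N)c1` gives 10 nM. Among the measured compounds shown here, the only single step on record is a 13-fold higher number from compound 2 to compound 3 (1.10 log units; beyond the scatter), a large weakening, but it adds an amino group to the same ring rather than replacing the methyl. Compound 4 `Cn1c(=O)c2nc(-c3ccc([N+](=O)[O-])cc3)[nH]c2n(C)c1=O` differs from compound 2 by nitro in place of methyl on an aromatic carbon. For the measured compounds named here, no measured pair swaps one group for another at this point of the ring, so the weakening seen for compound 3 serves only as a loose guide. A moderate weakening is expected, a 3.8-fold higher number from compound 2 to compound 4 (0.57 log units; beyond the scatter). For compound 4 a value of 3 nM is therefore estimated, within a range from 0.8 nM to 12 nM.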

Compound 4, half-maximal inhibitory concentration: 8 nM
Estimate against measurement, compound 4: 2.7-fold (0.43 log units) below; the range from low to high includes it.
By their numbers in this assay, from the lowest: compound 1; then compound 2; then compounds 4 and 3 (each within the scatter of the next).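

In this assay, swapping the methyl itself for nitro gives a 10-fold higher number from compound 2 to compound 4 (1.00 log units; beyond the scatter) and so shows that this place, on an aromatic carbon para to a large group, responds to a direct replacement. Among the compounds shown here, until now the only step on record was an added amino group on the same ring, with a 13-fold higher number from compound 2 to compound 3 (1.10 log units; beyond the scatter) as its result. No measurement on hand explains the size of this step.

From the compounds shown here alone, whether an amine, a carboxylic acid or a fluorine in place of the methyl would keep the number closer to that of compound 2 stays open. So does whether nitro has the same effect on the core of compound 1, which carries longer chains.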